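Swapping one ring for another on a shared core

This account rests on a few compounds, and the source may have more. Where it says the series, first, only, none or still open, it means among the compounds named here.

In a functional assay on K562 cells (Homo sapiens) for inhibition, with a stated time of 72 h (on this read-out lower numbers stand for stronger inhibition and higher numbers for weaker inhibition), compound 1 `NC1CCC(Nc2nc(NCc3ccc(Br)cc3)c3ncn(C4CCCC4)c3n2)CC1` gives 1170 nM and compound 2 `NC1CCC(Nc2nc(NCc3ccc(-n4cccn4)cc3)c3ncn(C4CCCC4)c3n2)CC1` gives 119 nM. Putting 1H-pyrazol-1-yl in place of bromo accounts for a 9.8-fold lower number from compound 1 to compound 2 (0.99 log units; beyond the scatter). Compound 3 `NC1CCC(Nc2nc(NCc3ccc(-c4cccc(F)c4)nc3)c3ncn(C4CCCC4)c3n2)CC1` gives 61 nM, within the scatter of compound 2 and beyond it from compound 1. Compound 4 `NC1CCC(Nc2nc(NCc3ccc(-c4ccco4)nc3)c3ncn(C4CCCC4)c3n2)CC1` carries furan-2-yl in place of 3-fluorophenyl on an aromatic carbon. Among the compounds with values here, the one measured step replaced bromo with a ring, not one ring with another, so it bears only weakly here. Compound 2 at 119 nM and compound 3 at 61 nM carry different rings, yet sit within the scatter. The expected result is therefore no change beyond the scatter, a 1.1-fold higher number from compound 3 to compound 4 (0.03 log units; within the scatter). The estimate for compound 4 is 65 nM, with an expected range of 22 nM to 190 nM.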

Compound 4, half-maximal inhibitory concentration: 67 nM
Compound 4: middle estimate off by 1.0-fold (0.01 log units), on the low side, within the range that was stated.
By their numbers in this assay, from the lowest: compounds 3, 4 and 2 (each within the scatter of the next); then compound 1.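

In this assay, on the carbon next to the ring nitrogen, five-membered furan-2-yl and six-membered 3-fluorophenyl cannot be told apart: a 1.1-fold higher number from compound 3 to compound 4 (0.04 log units; within the scatter). Exchanging the whole 4-(1H-pyrazol-1-yl)phenyl for 6-(furan-2-yl)pyridin-3-yl also stays within the scatter, a 1.8-fold lower number from compound 2 to compound 4 (0.25 log units; within the scatter), whereas exchanging 4-bromophenyl for it gives a 17-fold lower number from compound 1 to compound 4 (1.24 log units; beyond the scatter), which leaves compound 1 apart from the three ring-bearing compounds. Nothing available explains these results. From the compounds shown here alone, whether a group without an aromatic ring at this carbon, such as an amine or a carboxylic acid, would fit these numbers stays open.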